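From chloro to trifluoromethyl on compound 2

The source may report more compounds than this note shows. Statements on the series, on what has been measured and on what is new or still open speak of the compounds shown alone.

compound 1 `Clc1ccccc1/C=N/c1sc2c(c1-c1nc3ccccc3s1)CCC2` - 138 ug/mL
compound 2 `Clc1ccc(/C=N/c2sc3c(c2-c2nc4ccccc4s2)CCCC3)cc1` - 431 ug/mL

In an ADME assay on HeLa cells (Homo sapiens) for cytotoxicity, read by MTT assay, with a stated time of 72 h (a lower number here means that less compound is tolerated, a higher number that more compound is tolerated), compound 2 has the higher of the two numbers, and the gap down to compound 1 lies beyond the scatter. Compound 3 `FC(F)(F)c1ccc(/C=N/c2sc3c(c2-c2nc4ccccc4s2)CCCC3)cc1` carries trifluoromethyl in place of chloro on an aromatic carbon, para to a large group (trifluoromethyl in place of chloro on an aromatic carbon). Going by the values given here, no measured pair shows this change, so the expectation rests on compound 2 at 431 ug/mL. The expected 1.1-fold lower number from compound 2 to compound 3 (0.05 log units; within the scatter) stays within the scatter, with no firm direction. Compound 3 is estimated at 380 ug/mL, with an expected range from 150 ug/mL to 900 ug/mL.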

Compound 3, half-maximal cytotoxic concentration: 369 ug/mL
Beside the measured number, compound 3's estimate is 1.0-fold (0.01 log units) above it; measured number inside the range.
By their numbers in this assay, from the lowest: compound 1; then compounds 3 and 2 (each within the scatter of the next).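

In this assay trifluoromethyl, with its 4 heavy atoms, replaces chloro, with 1 heavy atom, on an aromatic carbon para to a large group, and this gives a 1.2-fold lower number from compound 2 to compound 3 (0.07 log units; within the scatter) as a step that stays within the scatter. At this position, then, the exchange of these two groups leaves the read-out unresolved. Nothing available explains the step. As far as these compounds go, whether an amine, a carboxylic acid or a methoxy group here would stay as close to compound 2 remains open. Also open, from the compounds shown here alone, is whether the same exchange would behave alike on the core of compound 1.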